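Azetidinyl for hydroxy on the pyridyl arm of compound 2

The compounds below may be only part of what the source reports. "The series", "measured", "known", "first", "only" and "open" are said of these compounds alone.

Measured compounds:
compound 1 `O=C(O)Cc1sc(C(c2ccc(F)cc2)c2ccc(F)cc2)nc1-c1cccc(F)c1`: 1.4 nM
compound 2 `O=C(O)Cc1sc(C(c2ccc(F)cc2)c2ccc(F)cc2)nc1-c1ccnc(O)c1`: 68 nM

Compound 1 was measured in an in vitro assay on HEK385-7 cells for displacement of a labelled ligand from prostaglandin D2 receptor 2 (Homo sapiens) (a higher number here means a weaker inhibitor, a lower number a stronger inhibitor), and gave 1.4 nM. Compound 2 is the weaker of the two in this assay, giving 68 nM. Within the data shown here, the only measured step, a 49-fold higher number from compound 1 to compound 2 (1.69 log units; beyond the scatter), shows that this aromatic arm is a sensitive place.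

Compound 3 `O=C(O)Cc1sc(C(c2ccc(F)cc2)c2ccc(F)cc2)nc1-c1ccnc(N2CCC2)c1` has not yet been measured. It differs from compound 2 by azetidin-1-yl in place of hydroxy on an aromatic carbon. Among the measured compounds shown here, no measured pair shares this exact change, so the expectation rests only on the sensitivity of this arm seen in the step from compound 1 to compound 2. Since compound 2 gave 68 nM after that change, compound 3 is expected to move back toward compound 1, and a step of a 5.7-fold lower number from compound 2 to compound 3 (0.75 log units; beyond the scatter) is estimated. Compound 3 is therefore expected to give about 12 nM, within a range of 2.5 nM to 60 nM.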

Compound 3, half-maximal inhibitory concentration: 660 nM
The estimate for compound 3 lay 55-fold (1.74 log units) below the measured number, and the stated range ends below it.
By their numbers in this assay, from the lowest: compound 1; then compound 2; then compound 3.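

In this assay, the step of a 9.7-fold higher number from compound 2 to compound 3 (0.99 log units; beyond the scatter) shows that the carbon next to the ring nitrogen is itself sensitive to what it carries, and that azetidin-1-yl in place of hydroxy moves the number further from compound 1, not back toward it. The step of a 470-fold higher number from compound 1 to compound 3 (2.67 log units; beyond the scatter) widens the span seen on this arm, leaving 2-(azetidin-1-yl)pyridin-4-yl as the weakest of the three arms shown. Nothing available here accounts for this loss.

The compounds shown leave open whether the loss goes with the four-membered ring or with any replacement of hydroxy at this carbon. An amino or methoxy group there, or a dimethylamino group as an open-chain counterpart of azetidin-1-yl, would help separate these readings.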